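Dropping the bromine of compound 1: compound 4

A few compounds are considered here, and "the series" means these few. Any claim that something is new, unique, unknown or untested is made for them only; others in the source may bear on it.

In a functional assay on HEK293 cells for agonist activity at Neuronal acetylcholine receptor; alpha3/beta4 (Homo sapiens), read by FLIPR (on this read-out lower numbers stand for an effect already at smaller amounts and higher numbers for an effect only at larger amounts of compound), compound 1 `COc1cc(N2C[C@@H]3CCNC[C@@H]32)cnc1Br` gives 2980 nM, the second highest of the three numbers shown. Compound 2 `N#Cc1cc(N2C[C@@H]3CCNC[C@@H]32)cnc1Br` gives 794 nM, and compound 3 `NC(=O)c1cc(N2C[C@@H]3CCNC[C@@H]32)cnc1Br` gives 23300 nM. The measured steps are a 3.8-fold lower number from compound 1 to compound 2 (0.57 log units; beyond the scatter), a 7.8-fold higher number from compound 1 to compound 3 (0.89 log units; beyond the scatter) and a 29-fold higher number from compound 2 to compound 3 (1.47 log units; beyond the scatter); each of them exchanges the methoxy, cyano or carbamoyl group on the shared core and leaves the bromine untouched.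

Compound 4 `COc1cncc(N2C[C@@H]3CCNC[C@@H]32)c1` differs from compound 1 by hydrogen in place of bromo on an aromatic carbon. Within the data shown here, no measured step alters this site, so none bears directly on the change; the measured steps only show that the series responds strongly to substitution on this ring. Without direct support, a modest move toward higher numbers is expected, a 2.0-fold higher number from compound 1 to compound 4 (0.30 log units; within the scatter). Compound 4 is estimated at 6000 nM, with a range of 1500 nM to 24000 nM.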

Compound 4, half-maximal effective concentration: 63500 nM
Compound 4: the middle estimate sits 11-fold (1.02 log units) below what was measured; the whole stated range lies below it.
By their numbers in this assay, from the lowest: compound 2; then compound 1; then compound 3; then compound 4.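

In this assay the bromo position proves to matter: with hydrogen in place of bromo, a 21-fold higher number from compound 1 to compound 4 (1.33 log units; beyond the scatter), a large step at the aromatic carbon next to the ring nitrogen and ortho to the methoxy group. Among these compounds, the earlier steps changed only the methoxy, cyano or carbamoyl group, so this is the first sign that the series also depends on the bromine. Nothing at hand accounts for the size of this step.

Still open, going by these compounds, is whether chlorine, a methyl group or an amine on this carbon would keep the number near that of compound 1. Also open, on these data alone, is whether losing the bromine from compound 2 or compound 3 would cost as much.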